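Working notes: from compound 3 to compound 4

The source may report more compounds than this note shows. Statements on the series, on what has been measured and on what is new or still open speak of the compounds shown alone.

Measured in a physicochemical assay for solubility, at pH 6.8; a higher number here means a more soluble compound, a lower number a less soluble compound:
- compound 1 `Cc1cncc(NC(=O)n2ccc3cc(Oc4ncnc5c4CCNC5)ccc32)c1`: 190000 nM
- compound 2 `CC(C)(C)c1cc(NC(=O)n2ccc3cc(Oc4ncnc5c4CCNC5)ccc32)n[nH]1`: 682000 nM
- compound 3 `CC1(c2cc(NC(=O)n3ccc4cc(Oc5ncnc6c5CCNC6)ccc43)n[nH]2)CC1`: 252000 nM

Compound 3 shows no clear gap at one end of this set, a 1.3-fold higher number from compound 1 to compound 3 (0.12 log units; within the scatter), and a clear one at the other, a 2.7-fold lower number from compound 2 to compound 3 (0.43 log units; beyond the scatter).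

The next structure, compound 4 `CC(C)(C)c1cc(NC(=O)n2ccc3cc(Oc4ncnc5c4CCNC5)ccc32)no1`, has 5-(tert-butyl)-1,2-oxazol-3-yl in place of 5-(1-methylcyclopropyl)-1H-pyrazol-3-yl on an amide-type nitrogen.

For the measured compounds named here, no measured step makes this exact exchange. The closest evidence is the exchange of groups on the amide-type nitrogen, a 3.6-fold higher number from compound 1 to compound 2 (0.56 log units; beyond the scatter), and the exchange of tert-butyl and 1-methylcyclopropyl seen in the step between compound 2 and compound 3. These steps are modest, and they do not settle a direction for an oxazole in place of a pyrazole. A step no larger than these is therefore expected, most likely none beyond the scatter. The estimated step is a 1.3-fold lower number from compound 3 to compound 4 (0.10 log units; within the scatter). The estimate for compound 4 is 200000 nM, with an expected range of 70000 nM to 600000 nM.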

Compound 4, solubility: 167000 nM
Compound 4: middle estimate off by 1.2-fold (0.08 log units), on the high side; the measured number falls inside the stated range.
By their numbers in this assay, from the lowest: compounds 4, 1 and 3 (each within the scatter of the next); then compound 2.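

For the compounds shown here, with the tert-butyl kept, 5-(tert-butyl)-1,2-oxazol-3-yl in place of 5-(tert-butyl)-1H-pyrazol-3-yl on the amide-type nitrogen gives the first reading of this ring exchange in this assay (a 4.1-fold lower number from compound 2 to compound 4 (0.61 log units; beyond the scatter)). The same group shows no step beyond the scatter against either of the other two groups (a 1.5-fold lower number from compound 3 to compound 4 (0.18 log units; within the scatter); a 1.1-fold lower number from compound 1 to compound 4 (0.06 log units; within the scatter)), so among these four compounds only compound 2 stands apart, with its steps to all the others beyond the scatter. No measurement here bears on the reason for this gap.

Going by these compounds alone, whether the gap between the pyrazole and the oxazole holds with another substituent on the ring remains open, since tert-butyl is the only group compared across that exchange. An amine or a carboxylic acid in place of tert-butyl would test this further.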